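The source may report more compounds than this note shows. Statements on the series, on what has been measured and on what is new or still open speak of the compounds shown alone.

Of the compounds shown here, three have so far been tested in a functional assay on LOX IMVI cells (Homo sapiens) for cytotoxicity, read by resazurin assay, with a stated time of 72 h (a lower number here means a stronger inhibitor, a higher number a weaker inhibitor), with the read-out given as a half-maximal inhibitory concentration. Compound 1 `COc1cc(/C=C/C(=O)OCCCCCCO[N+](=O)[O-])ccc1O` gives > 50000 nM, which is a limit of the assay and not a number. Compound 2 `COc1cc(/C=C/C(=O)OCCCO[N+](=O)[O-])ccc1OCCCO[N+](=O)[O-]` gives > 50000 nM, which is also only a limit. Compound 3 `O=C(/C=C/c1ccc(OCCCCCCO[N+](=O)[O-])c(O)c1)OCCCCCCO[N+](=O)[O-]` gives > 50000 nM, again a limit. Compound 2 therefore has no exact place on the scale, and the three cannot be ranked against one another. The whole picture so far is the limit of > 50000 nM in this assay, at which 3 of the 3 values shown sit.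

Compound 4 `COc1cc(/C=C/C(=O)OCCCO[N+](=O)[O-])ccc1O` differs from compound 2 in one place: hydrogen in place of 3-(nitrooxy)propyl on an oxygen on an aromatic ring. In words, hydrogen stands in place of 3-(nitrooxy)propyl on an oxygen on an aromatic ring, so that 3-(nitrooxy)propoxy becomes hydroxy. Among the compounds with values here, no measured step between related compounds is available to show how large such a change might be. The expectation rests instead on compound 2, whose result of > 50000 nM is a limit. The estimated step of a number no higher from compound 2 to compound 4 (the limit leaves the size open) in this assay is none beyond the scatter of repeated measurements, with neither direction favoured. For compound 4 the expected value is 50000 nM, with an estimated range of 20000 nM to 100000 nM, and the result may well be reported only as a limit.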

Compound 4, half-maximal inhibitory concentration: 29500 nM
Compound 4: middle estimate off by 1.7-fold (0.23 log units), on the high side; the range from low to high includes it.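

In this assay, within the data shown here, compound 4 is the first compound here to give a number rather than a limit, with a value of 29500 nM. Hydrogen in place of 3-(nitrooxy)propyl on an oxygen on an aromatic ring gives an at least 1.6-fold lower number from compound 2 to compound 4 (0.22 log units; that floor lies within the scatter), while nitrooxy in place of 3-(nitrooxy)propyl on a saturated chain carbon, three bonds along the chain from an oxygen next to a carbonyl group, gives an at least 1.6-fold lower number from compound 1 to compound 4 (0.22 log units; that floor lies within the scatter). Both steps are floors that lie within the scatter, so the result places a measurable value on this core without showing that either change has a real effect, and most of the series still rests at one limit: the limit of > 50000 nM in this assay, at which 3 of the 4 values shown sit.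

Going by these compounds, the true size of both steps stays unknown, as compound 1 and compound 2 have limits and not numbers. On these data alone, it also remains open whether a chain ending in an amine or a carboxylic acid, set on that aromatic oxygen or in place of the nitrooxy end of the ester chain, would move the number beyond the scatter.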